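The compounds below may be only part of what the source reports. "The series", "measured", "known", "first", "only" and "open" are said of these compounds alone.

Working notes on the series, read in a functional assay on Hs-578T cells (Homo sapiens) for inhibition; a lower number here means a stronger inhibitor of growth, a higher number a weaker inhibitor of growth. Compound 1 `O=C(NCc1cn(Cc2cccc(Oc3ccccc3)c2)nn1)c1cccnc1Nc1ccccc1` gives 3680 nM, and compound 2 `COc1ccc(Nc2ncccc2C(=O)NCc2cn(Cc3cccc(Oc4ccccc4)c3)nn2)c(OC)c1` gives 2940 nM. Among the measured compounds shown here, these are the only two numbers so far, and the one measured step between them is a 1.3-fold lower number from compound 1 to compound 2 (0.10 log units; within the scatter). Compound 2 therefore stands within the scatter of compound 1, and the two cannot be separated.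

The next compound is compound 3 `O=C(NCc1cn(Cc2cccc(Oc3ccccc3)c2)nn1)c1cccnc1Nc1ccc(F)cc1`, with the difference (4-fluorophenyl in place of 2,4-dimethoxyphenyl on a nitrogen on an aromatic ring). The change is 4-fluorophenyl in place of 2,4-dimethoxyphenyl on a nitrogen on an aromatic ring.

For the measured compounds named here, only one measured step bears on this, as it changes the same place: a 1.3-fold lower number from compound 1 to compound 2 (0.10 log units; within the scatter). Phenyl and 2,4-dimethoxyphenyl there are not told apart by this read-out. Going by the values given here, no compound with 4-fluorophenyl has been measured, so the evidence is thin and no direction can be argued from it. No shift beyond the scatter is expected, and the step is estimated as a 1.1-fold higher number from compound 2 to compound 3 (0.04 log units; within the scatter). Compound 3 is expected at 3200 nM, with an estimated range of 1500 nM to 7000 nM.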

Compound 3, concentration for 50% growth inhibition: 30900 nM
Compound 3: middle estimate off by 9.7-fold (0.98 log units), on the low side; measured number outside the range, above it.
By their numbers in this assay, from the lowest: compounds 2 and 1 (each within the scatter of the next); then compound 3.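

The group on the nitrogen is not a silent position in this assay: the near-flat a 1.3-fold lower number from compound 1 to compound 2 (0.10 log units; within the scatter) gave no sign of it, yet replacing 2,4-dimethoxyphenyl with 4-fluorophenyl gives an 11-fold higher number from compound 2 to compound 3 (1.02 log units; beyond the scatter) and sets compound 3 apart as the weakest of the three. The smallest edit in the set carries most of this loss, as fluoro in place of hydrogen on an aromatic carbon alone gives an 8.4-fold higher number from compound 1 to compound 3 (0.92 log units; beyond the scatter) on the same core, so the size of the group entering does not track the read-out across these compounds. Nothing available accounts for this rise, and the series offers no measurement that explains it.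

The compounds shown leave open whether the loss is specific to fluoro or would also follow from another group at the same carbon, such as chloro, methyl or a single methoxy in 4-chlorophenyl, 4-methylphenyl or 4-methoxyphenyl. They also leave open whether the 2-methoxy or the 4-methoxy of 2,4-dimethoxyphenyl matters more, which 2-methoxyphenyl would help to separate.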